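The compounds below may be only part of what the source reports. "The series", "measured", "known", "first", "only" and "open" are said of these compounds alone.

Compound 3 `COc1cccc(CNCCCNc2ccnc3cc(Oc4ccc(F)cc4)ccc23)c1O` is measured in a physicochemical assay for solubility, with a stated time of 18 h, at pH 7.4 (a higher number here means a more soluble compound, a lower number a less soluble compound), where compound 3 gives 14500 nM. For comparison, compound 2 `COc1ccc(Oc2ccc3c(NCCCNCc4cccc(OC)c4O)ccnc3c2)cc1` gives 14500 nM and compound 1 `COc1cccc(CNCCCNc2ccnc3cc(C4CCCCC4)ccc23)c1O` gives 4200 nM, so compound 3 stands level with compound 2, the two together at the top of the three numbers, while a 3.5-fold higher number from compound 1 to compound 3 (0.54 log units; beyond the scatter). Compound 4 `COc1cccc(CNCCCNc2ccnc3cc(-c4ccccc4)ccc23)c1O` differs from compound 3 in a single place: phenyl in place of 4-fluorophenoxy on an aromatic carbon. For the measured compounds named here, two measured steps touch this same position. a 3.5-fold higher number from compound 1 to compound 3 (0.54 log units; beyond the scatter), and likewise a 3.5-fold higher number from compound 1 to compound 2 (0.54 log units; beyond the scatter); by contrast no change at the digits printed from compound 2 to compound 3 (within the scatter). Going by the values given here, compound 4 carries at this position neither a cyclohexyl nor a 4-fluorophenoxy or 4-methoxyphenoxy but a phenyl with no hydrogen-bond acceptor, so no measured step covers it exactly; the nearest guide is compound 1, whose value of 4200 nM sits a step below compound 3. For compound 4 the expected step is a 3.2-fold lower number from compound 3 to compound 4 (0.51 log units; beyond the scatter), a modest drop with wide uncertainty. Compound 4 is estimated at 4500 nM, within a range of 1500 nM to 14000 nM.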

Compound 4, solubility: 32000 nM
Compound 4: the middle estimate sits 7.1-fold (0.85 log units) below what was measured; the measured number lies above the stated range.
By their numbers in this assay, from the lowest: compound 1; then compounds 2 and 3 (each within the scatter of the next); then compound 4.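

In this assay, compound 4 gives the highest number of the four, with a 2.2-fold higher number from compound 3 to compound 4 (0.34 log units; beyond the scatter), a 2.2-fold higher number from compound 2 to compound 4 (0.34 log units; beyond the scatter) and a 7.6-fold higher number from compound 1 to compound 4 (0.88 log units; beyond the scatter). The earlier compounds shown here left open the reading that a group with a hydrogen-bond acceptor at this position goes with the higher number, but compound 4 goes against that reading, since its phenyl has no hydrogen-bond acceptors and its oxygen-free link joins the ring straight to the shared core. Nothing available here explains why the number rises with this change.

As far as these compounds go, what remains open is whether the phenyl result holds once the ring itself carries a substituent, such as an amine or a carboxylic acid. A pyridyl group in the same place, with a ring nitrogen in place of one ring carbon, is equally untested by the compounds shown here.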